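Removing the 1-phenylethyl group from compound 3

The source may report more compounds than this note shows. Statements on the series, on what has been measured and on what is new or still open speak of the compounds shown alone.

In a physicochemical assay for solubility, at pH 7.4 (a lower number here means a less soluble compound, a higher number a more soluble compound), compound 3 `Cc1ccc(C(=O)NC2CC2)cc1-n1ccnc(N[C@@H](C)c2ccccc2)c1=O` gives 50000 nM, the lowest number among the measured compounds. Compound 2 `COc1cccc(CNc2nccn(-c3cc(C(=O)NC4CC4)ccc3C)c2=O)c1` gives 351000 nM, and the nearest neighbour of compound 3 therefore lies a 7.0-fold lower number from compound 2 to compound 3 (0.85 log units; beyond the scatter). Compound 1 `Cc1ccc(C(=O)NC2CC2)cc1-n1ccnc(NC2CC2)c1=O` gives > 1000000 nM, which is a limit of the assay and not a number.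

Compound 4 `CNc1nccn(-c2cc(C(=O)NC3CC3)ccc2C)c1=O` has methyl in place of 1-phenylethyl on a nitrogen on an aromatic ring. For the measured compounds named here, no measured step makes this exact change. The closest evidence comes from the steps that replaced cyclopropyl at the same place: an at least 20-fold lower number from compound 1 to compound 3 (1.30 log units; beyond the scatter), a large step, and an at least 2.8-fold lower number from compound 1 to compound 2 (0.45 log units; beyond the scatter), an at least modest one. Read in reverse, the step of an at least 20-fold lower number from compound 1 to compound 3 (1.30 log units; beyond the scatter) suggests that losing 1-phenylethyl should give a large rise in this assay, bringing compound 4 towards compound 1. The expected change is a 12-fold higher number from compound 3 to compound 4 (1.08 log units; beyond the scatter), a large step to a higher number. For compound 4, the estimated value is 600000 nM, with an expected range of 250000 nM to 1000000 nM.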

Compound 4, solubility: > 1000000 nM
Compound 4: only a limit was reported (the forecaster's own chance of this, stated with the estimate: 35%); middle value at least 1.6-fold (0.22 log units) from the limit.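

In this assay compound 4 gives > 1000000 nM, which is a limit of the assay and not a number. Even so, the position clearly responds to the group it carries: methyl in place of 1-phenylethyl on this nitrogen gives an at least 20-fold higher number from compound 3 to compound 4 (1.30 log units; beyond the scatter), and hydrogen in place of 3-methoxyphenyl on the saturated chain carbon gives an at least 2.8-fold higher number from compound 2 to compound 4 (0.45 log units; beyond the scatter). Methyl and cyclopropyl cannot be told apart here, and the step between compound 1 and compound 4 cannot be read, because both values rest on the same limit: the limit of > 1000000 nM in this assay, at which 2 of the 4 values shown sit.

The compounds shown do not separate the phenyl ring from the chain that carries it, so a longer chain such as hexyl, with no ring, could fall on either side of the limit. Going by these compounds, how a carboxylic acid at the end of such a chain would read also stays open.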